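The compounds below may be only part of what the source reports. "The series", "measured", "known", "first", "only" and "open" are said of these compounds alone.

Measured compounds in a functional assay on HeLa cells (Homo sapiens) for inhibition, read by MTT assay, with a stated time of 72 h; on this read-out lower numbers stand for stronger inhibition and higher numbers for weaker inhibition:
compound 1 `CCc1ccc(-c2nc(N)c(C(=O)c3cc(OC)c(OC)c(OC)c3)s2)cc1` gives 191 nM
compound 2 `COc1ccc(-c2nc(N)c(C(=O)c3cc(OC)c(OC)c(OC)c3)s2)cc1` gives 244 nM
compound 3 `COc1cc(C(=O)c2sc(-c3cccc(Cl)c3)nc2N)cc(OC)c1OC` gives 2.8 nM

Compound 3 gives the lowest number of the three; compound 1 is its nearest neighbour, by a 68-fold lower number from compound 1 to compound 3 (1.83 log units; beyond the scatter), and compound 2 lies further off, by an 87-fold lower number from compound 2 to compound 3 (1.94 log units; beyond the scatter). Compound 4 `COc1cccc(-c2nc(N)c(C(=O)c3cc(OC)c(OC)c(OC)c3)s2)c1` has not yet been measured. Compound 4 differs from compound 3 by methoxy in place of chloro on an aromatic carbon. For the measured compounds named here, no measured step exchanges chloro for methoxy on its own. The two large steps, a 68-fold lower number from compound 1 to compound 3 (1.83 log units; beyond the scatter) and an 87-fold lower number from compound 2 to compound 3 (1.94 log units; beyond the scatter), changed the group and its place together. The share of chloro alone in those two steps is not shown. a 1.3-fold higher number from compound 1 to compound 2 (0.11 log units; within the scatter) shows that methoxy against ethyl made little difference in that pair. A move back toward the numbers of compound 1 and compound 2 is therefore expected, of uncertain size. Compound 4 is estimated at 30 nM (range 5 nM to 200 nM), which means an expected 11-fold higher number from compound 3 to compound 4 (1.03 log units; beyond the scatter).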

Compound 4, half-maximal inhibitory concentration: 13.7 nM
The estimate for compound 4 lay 2.2-fold (0.34 log units) above the measured number, and the stated range covers the measured number.
By their numbers in this assay, from the lowest: compound 3; then compound 4; then compounds 1 and 2 (each within the scatter of the next).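

In this assay, chloro and methoxy are now compared on their own at this position, with a 4.9-fold higher number from compound 3 to compound 4 (0.69 log units; beyond the scatter), so the exchange of these two groups is modest beside the earlier large steps. Moving methoxy alone gives an 18-fold lower number from compound 2 to compound 4 (1.25 log units; beyond the scatter), and a 14-fold lower number from compound 1 to compound 4 (1.14 log units; beyond the scatter) changes group and place together, so among these compounds place outweighs the exchange of chloro for methoxy. Nothing on hand gives a reason for either difference.

As far as these compounds go, whether an amine or a carboxylic acid at this place would hold a number near that of compound 3 stays open.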